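The source may hold more compounds than are shown below. What is called first, only, known or untested is meant among the compounds shown, and "the series" means these compounds.

In an ADME assay on the whole organism (Mus musculus, strain CD-1) for pharmacokinetics, at a dose of 10 mg/kg by the oral route (a higher number here means that a larger share of the oral dose reaches the circulation, a lower number that a smaller share of the oral dose reaches the circulation), compound 1 `COc1cc([C@](O)(CCN(C)C)[C@@H](c2cc3cc(Br)ccc3nc2OC)c2cccc(OC)c2F)cc(OC(C)C)n1` gives 43% and compound 2 `CCSc1cc([C@](O)(CCN(C)C)[C@H](c2ccccc2)c2cc3cc(Br)ccc3nc2OC)cc(SCC)n1` gives 24%, the lower of the two numbers, with a gap beyond the usual scatter. Compound 3 `CCSc1cc([C@](O)(CCN(C)C)[C@@H](c2cc3cc(Br)ccc3nc2OC)c2cccc(OC)c2F)cc(SCC)n1` has 2-fluoro-3-methoxyphenyl in place of the phenyl of compound 2: 2-fluoro-3-methoxyphenyl in place of phenyl on a saturated chain carbon bound to an aromatic carbon and a saturated chain carbon. Within the data shown here, no measured pair shows this change alone. However, compound 1 also carries 2-fluoro-3-methoxyphenyl and gives 43%, so a modest rise in this assay is expected, one that stays within the scatter: a number 9 percentage points higher from compound 2 to compound 3 (within the scatter). For compound 3 the estimated value is 33%, with an expected range of 18% to 48%.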

Compound 3, oral bioavailability: 25%
Compound 3: middle estimate off by 8 percentage points, on the high side, within the range that was stated.
By their numbers in this assay, from the lowest: compounds 2 and 3 (each within the scatter of the next); then compound 1.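

In this assay, 2-fluoro-3-methoxyphenyl in place of phenyl on this saturated chain carbon gives a number 1 percentage points higher from compound 2 to compound 3 (within the scatter), and the two sulfur-bearing compounds stay level. Compound 1 and compound 3 share that group and differ in the other six-membered aromatic ring group, where the sulfur-bearing group in place of the oxygen-bearing one gives a number 18 percentage points lower from compound 1 to compound 3 (beyond the scatter). Nothing measured here explains either step. Still open, as far as these compounds go, is which of the two sulfur atoms matters more, and whether a pyrrolidine at the end of the amine chain would alter the oral share.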